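The source may report more compounds than this note shows. Statements on the series, on what has been measured and on what is new or still open speak of the compounds shown alone.

The series is small, and only two of its three results are true numbers. In a functional assay on HeLa cells (Homo sapiens) for inhibition, read by MTT assay, with a stated time of 48 h (on this read-out higher numbers stand for weaker inhibition and lower numbers for stronger inhibition), compound 1 `O=C(/C=C/c1ccccc1)c1ccc[nH]1` gives > 100000 nM as a limit of the assay and not as a number. Compound 2 `CN(C)c1ccc(/C=C/C(=O)c2ccco2)cc1` gives 20000 nM and compound 3 `O=C(/C=C/c1cccc([N+](=O)[O-])c1)c1ccco1` gives 22000 nM in this assay, and these two numbers lie within the usual scatter of each other. Compound 3 therefore stands level with compound 2, in the micromolar part of the scale where inhibition is modest.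

The next structure is compound 4 `O=C(/C=C/c1ccccc1)c1ccco1`, which has hydrogen in place of nitro on an aromatic carbon. Going by the values given here, no measured pair shows this change alone, so any forecast rests on indirect evidence. The best guide is that compound 2 at 20000 nM and compound 3 at 22000 nM carry different groups on the six-membered aromatic ring and still read alike. This suggests only a small shift, perhaps leaning towards weaker inhibition. The expected move is a 1.4-fold higher number from compound 3 to compound 4 (0.13 log units; within the scatter) and it would probably stay within the scatter. A result at the limit of the assay cannot be ruled out. For compound 4 the estimated value is 30000 nM with an expected range from 12000 nM to 80000 nM in this assay.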

Compound 4, half-maximal inhibitory concentration: > 100000 nM
Compound 4 gave a limit, no number; the forecaster's own chance of this, stated with the estimate: 15%; at least 3.3-fold (0.52 log units) between middle value and limit.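

In this assay, putting hydrogen in place of nitro on this aromatic carbon, meta to a group of 9 heavy atoms, gives an at least 4.5-fold higher number from compound 3 to compound 4 (0.65 log units; beyond the scatter). Putting hydrogen in place of dimethylamino on an aromatic carbon points the same way and gives an at least 5.0-fold higher number from compound 2 to compound 4 (0.69 log units; beyond the scatter). Going by these compounds alone, the earlier compounds showed only that two quite different groups on the six-membered aromatic ring read alike, whereas these steps show that the ring without either group gives clearly weaker inhibition, so what matters here is having a group there at all, and not only which group it is.

The step that swaps the 1H-pyrrol-2-yl of compound 1 for the furan-2-yl of compound 4 cannot be read, because both compounds sit at the same limit, which is not a number: the limit of > 100000 nM in this assay, at which 2 of the 4 values shown sit. The compounds shown leave open whether a simple methyl, a chlorine atom or a carboxylic acid on the same ring would also hold the inhibition seen with nitro and dimethylamino, and how much of the full size of each step lies beyond that limit.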